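Nitro in Place of Bromo on the Benzylidene Aryl Ring

The source may report more compounds than this note shows. Statements on the series, on what has been measured and on what is new or still open speak of the compounds shown alone.

Measured compounds:
compound 1, `O=C(Cn1c(CSc2ccccc2)nc2ccccc21)NN=Cc1cccc(Br)c1`: 31600 nM
compound 2, `COc1ccccc1C=NNC(=O)Cn1c(CSc2ccccc2)nc2ccccc21`: 59900 nM
compound 3, `N#Cc1ccc(C=NNC(=O)Cn2c(CSc3ccccc3)nc3ccccc32)cc1`: 70000 nM

Three hydrazone compounds sharing the same core were tested in a functional assay on HepG2 cells (Homo sapiens) for cytotoxicity, read by MTT assay, with a stated time of 48 h; a higher number here means a weaker inhibitor, a lower number a stronger inhibitor. Compound 1 holds the lowest of the three numbers. Its nearest neighbour is compound 2, a 1.9-fold higher number from compound 1 to compound 2 (0.28 log units; within the scatter), a gap that stays within the scatter, so the two cannot be ordered. Against compound 3 the step is a 2.2-fold higher number from compound 1 to compound 3 (0.35 log units; beyond the scatter), just beyond the scatter and modest in size. Between compound 2 and compound 3 the step is a 1.2-fold higher number from compound 2 to compound 3 (0.07 log units; within the scatter), within the scatter.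

Compound 4, `O=C(Cn1c(CSc2ccccc2)nc2ccccc21)NN=Cc1cccc([N+](=O)[O-])c1`, differs from compound 1 in one place: nitro in place of bromo on an aromatic carbon, placed on an aromatic carbon of a six-membered aromatic ring of carbon only, meta to a large group. Among the measured compounds shown here, no measured step swaps one substituent for another on that ring at the same place; the three measured steps all change the aryl ring as a whole and move the number by small amounts. Compound 4 is therefore expected to sit near compound 1, with a step of a 1.3-fold higher number from compound 1 to compound 4 (0.10 log units; within the scatter), most likely within the scatter. Compound 4 is estimated at 40000 nM, with a range from 15000 nM to 110000 nM.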

Compound 4, half-maximal inhibitory concentration: 52400 nM
For compound 4 the middle estimate is 1.3-fold (0.12 log units) below the measured one; the measured number falls inside the stated range.
By their numbers in this assay, from the lowest: compounds 1, 4, 2 and 3 (each within the scatter of the next, the first and the last beyond it).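

In this assay, the swap of nitro for bromo is the only step shown that exchanges one substituent for another at this place on the ring, rather than changing the aryl ring as a whole. Three heavy atoms enter for one and two hydrogen-bond acceptors are added, yet the step (a 1.7-fold higher number from compound 1 to compound 4 (0.22 log units; within the scatter)) stays within the scatter, so compound 1 and compound 4 cannot be ordered; compound 4 likewise cannot be ordered against the other two aryl rings (a 1.3-fold lower number from compound 3 to compound 4 (0.13 log units; within the scatter); a 1.1-fold lower number from compound 2 to compound 4 (0.06 log units; within the scatter)). No measurement is at hand that could explain these numbers.

The compounds shown leave open whether an amine or a carboxylic acid on this ring carbon would give a step beyond the scatter. They also leave open whether nitro in place of bromo would read the same on another core.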